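Swapping Methoxy for Trifluoromethyl on a Kinase Inhibitor Core

This account rests on a few compounds, and the source may have more. Where it says the series, first, only, none or still open, it means among the compounds named here.

Of the compounds shown here, three built on one shared core have been measured in an assay on Sf9 cells for inhibition of serine/threonine-protein kinase 4 (Homo sapiens), read by luminescence and ADP-Glo, with a stated time of 1 h, in the presence of a further agent that is not named here; a higher number here means a weaker inhibitor, a lower number a stronger inhibitor. Compound 1 `COc1cccc(C2C(=O)N(C)c3cnc(Nc4ccc(S(N)(=O)=O)cc4)nc3N2C)c1` gives 954 nM in this assay. Compound 2 `CN1C(=O)C(c2cccc(C(F)(F)F)c2)N(C)c2nc(Nc3ccc(S(N)(=O)=O)cc3)ncc21` differs from compound 1 in a single place, (trifluoromethyl in place of methoxy on an aromatic carbon), and in this assay compound 2 gives 2710 nM. That exchange produced a 2.8-fold higher number from compound 1 to compound 2 (0.45 log units; beyond the scatter). Compound 3 `COc1ccccc1C1C(=O)N(C)c2cnc(Nc3ccc(S(N)(=O)=O)cc3)nc2N1C` is made of the same atoms as compound 1, joined differently, (2-methoxyphenyl in place of 3-methoxyphenyl on a saturated ring carbon); in this assay compound 3 gives 251 nM. This rearrangement gave a 3.8-fold lower number from compound 1 to compound 3 (0.58 log units; beyond the scatter), and measured against compound 2 it reads an 11-fold lower number from compound 2 to compound 3 (1.03 log units; beyond the scatter). Among these three, compound 3 carries the lowest number.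

Compound 4 `CN1C(=O)C(c2ccccc2C(F)(F)F)N(C)c2nc(Nc3ccc(S(N)(=O)=O)cc3)ncc21` has not yet been measured. It is related to compound 3 by trifluoromethyl in place of methoxy on an aromatic carbon. Within the data shown here, this is the same kind of change as the one between compound 1 and compound 2, but the surroundings differ: in compound 1 the group sits meta to a large group, whereas in compound 3 it sits ortho to a large group. The single measured example of this exchange is the only guide, and whether the same exchange ortho to a large group behaves alike is not shown by these three compounds. On that basis the step from compound 3 to compound 4 is expected to be a 3.0-fold higher number from compound 3 to compound 4 (0.48 log units; beyond the scatter), resting on the measured step of a 2.8-fold higher number from compound 1 to compound 2 (0.45 log units; beyond the scatter). Compound 4 is therefore estimated at 750 nM in this assay, with a likely range from 300 nM to 2000 nM.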

Compound 4, half-maximal inhibitory concentration: 56 nM
Compound 4: the middle estimate sits 13-fold (1.13 log units) above what was measured, outside the stated range (below it).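

The exchange of methoxy for trifluoromethyl did not carry over from one core to the other in this assay, where the same swap moved the number in opposite directions: the same change on two cores in this assay, a 2.8-fold higher number (0.45 log units; beyond the scatter) from compound 1 to compound 2 and a 4.5-fold lower number (0.65 log units; beyond the scatter) from compound 3 to compound 4, 13-fold (1.10 log units) apart, beyond the scatter of two such steps

The new step, a 4.5-fold lower number from compound 3 to compound 4 (0.65 log units; beyond the scatter), joins two larger ones, a 48-fold lower number from compound 2 to compound 4 (1.68 log units; beyond the scatter) and a 17-fold lower number from compound 1 to compound 4 (1.23 log units; beyond the scatter), so compound 4, which carries the 2-(trifluoromethyl)phenyl group, is the strongest inhibitor of the four. Together, these two pairs show that in this small set the result of the swap depends on where the group sits on the aromatic ring, but they do not show why, and two pairs cannot set a rule for other groups or for other compounds in the series.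

The compounds shown leave open whether a chlorine, a methyl or a nitrile in the place held by trifluoromethyl in compound 4 would give a number as low as that of compound 4. They also leave open how a plain phenyl group, with nothing on the ring, would compare with the 2-methoxyphenyl of compound 3 and the 2-(trifluoromethyl)phenyl of compound 4.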